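A Propylamino Swap on a Thiocarbonyl Carbon

A few compounds are considered here, and "the series" means these few. Any claim that something is new, unique, unknown or untested is made for them only; others in the source may bear on it.

Compound 1 `CN1C(=O)/C(=N\NC(=S)Nc2ccccc2)c2ccccc21` gives > 25000 nM in an ADME assay on RD cells (Homo sapiens) for cytotoxicity; on this read-out higher numbers stand for lower toxicity in this test and lower numbers for higher toxicity in this test; this value is a limit of the assay, not a number. Compound 2 `CCN(CC)C(=S)N/N=C1\C(=O)Nc2ccccc21` gives > 25000 nM in this assay; this too is a limit. Compound 3 `CCN1C(=O)/C(=N\NC(=S)Nc2ccccc2)c2ccccc21` gives > 25000 nM in this assay; again a limit.

Compound 2 thus stands where every measured compound stands: at the limit of > 25000 nM in this assay, at which 3 of the 3 values shown sit. Nothing in the numbers sets it apart from compound 1 or compound 3, and no ordering among the three can be read.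

Compound 4 `CCCNC(=S)N/N=C1\C(=O)Nc2ccccc21` is not yet measured. It differs from compound 2 by one change: propylamino in place of diethylamino on a thiocarbonyl carbon.

Among the measured compounds shown here, only one measured step exists, a step that the two limits leave unreadable from compound 1 to compound 3, and it does not touch the thiocarbonyl carbon; its size cannot be read because both ends are limits. For the measured compounds named here, no measured step therefore bears on the change from compound 2 to compound 4, and there is no evidence that the thiocarbonyl substituent moves the read-out at all.

With all three measured compounds at the limit, the expectation for compound 4 is a step that the limit leaves unreadable from compound 2 to compound 4, that is, nothing beyond the scatter. Compound 4 is estimated at 30000 nM, most likely again reported only as a limit, with a range from 10000 nM to 100000 nM.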

Compound 4, half-maximal cytotoxic concentration: > 25000 nM
Compound 4: only a limit was reported; the forecaster's own chance of this, stated with the estimate: 75%; the middle value does not contradict the limit.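

Compound 4 gives > 25000 nM in this assay, and this value is a limit, not a number. Compound 2 also has only a limit, so the size of the swap between compound 2 and compound 4 cannot be read. Whether any change among these compounds moves the read-out stays open, because all share one result: the limit of > 25000 nM in this assay, at which 4 of the 4 values shown sit.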